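The compounds below may be only part of what the source reports. "The series", "measured", "known", "first", "only" and "open" are said of these compounds alone.

Measured so far in a functional assay on Hs-578T cells (Homo sapiens) for cytotoxicity, read by sulforhodamine B assay, with a stated time of 48 h, tested at 10 uM; on this read-out lower numbers stand for a stronger effect and higher numbers for a weaker effect at the one concentration tested:
compound 1 `COc1ccc(-c2cc(/C=C/C(=O)c3ccc(N)cc3)[nH]n2)cc1` gives 22%
compound 2 `COc1ccc(-c2cc(/C=C/C(=O)c3ccc(N)cc3)[nH]n2)cc1OC` gives 40%
compound 3 `COc1cc(C(=O)/C=C/c2cc(-c3cc(OC)c(OC)c(OC)c3)n[nH]2)cc(OC)c1OC` gives 10%

Compound 3 has the lowest number of the three, beyond the scatter against both others; how its core differs from the core of compound 2 is not broken down here. Between compound 2 and compound 1 the change is hydrogen in place of methoxy on an aromatic carbon and the step is a number 18 percentage points lower from compound 2 to compound 1 (beyond the scatter), a fall beyond the scatter.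

Compound 4 `COc1ccc(-c2cc(/C=C/C(=O)c3cc(OC)c(OC)c(OC)c3)[nH]n2)cc1OC` is not yet measured in this assay. It differs from compound 3 by hydrogen in place of methoxy on an aromatic carbon. This is the same kind of change as that from compound 2 to compound 1, not the same one: the place in compound 3 is also meta to a methoxy group, which is not so for the place in compound 2.

For compound 4 in this assay a step of a number 4 percentage points lower from compound 3 to compound 4 (within the scatter) is expected. The step is expected to be smaller than the earlier one because compound 3 already stands at 10% and the number has little room to fall. The estimate for compound 4 is 6%, with a range from 0% to 16%.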

Compound 4, a percentage reported as activity, at one concentration (the size of the read-out at that concentration, not a potency): 9%
For compound 4 the middle estimate is 3 percentage points below the measured one; the measured number falls inside the stated range.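

In this assay, hydrogen in place of methoxy on an aromatic carbon of the core of compound 3 gives a number 1 percentage points lower from compound 3 to compound 4 (within the scatter) and the size of the step seen on the other core does not carry over. The two steps differ: the same change on two cores in this assay, a number 18 percentage points lower (beyond the scatter) from compound 2 to compound 1 and a number 1 percentage points lower (within the scatter) from compound 3 to compound 4, 17 percentage points apart, beyond the scatter of two such steps

This shows that the size of the step for this change cannot be transferred from one core to the other in this series. It does not show why the steps differ, and two pairs cannot tell whether the low numbers of compound 3 and compound 4 leave too little room for a fall, or whether the core itself, or the place of the change, sets the size of the step.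

Open, on these data alone, is whether hydroxy, ethoxy or fluorine in the same place would give steps that also depend on the core. Also open, as far as these compounds go, is whether a core with a number further from the low end, carrying the same methoxy pattern as compound 3, would show a larger step for this change.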